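The compounds below may be only part of what the source reports. "The series", "measured", "known", "first", "only" and "open" are said of these compounds alone.

Measured so far in a functional assay on CCRF-CEM cells (Homo sapiens) for antiproliferative activity, read by cell counting, with a stated time of 96 h; a lower number here means a stronger inhibitor, a higher number a weaker inhibitor:
- compound 1 `CC(=O)c1ccc(Oc2ccccc2NC(C)=C2C(=O)CC(c3ccccc3)CC2=O)cc1` gives 220 nM
- compound 2 `COc1ccc(Oc2ccccc2NC(C)=C2C(=O)CC(c3ccccc3)CC2=O)cc1OC` gives 160 nM
- compound 3 `COc1cc(Oc2ccccc2NC(C)=C2C(=O)CC(c3ccccc3)CC2=O)ccc1N` gives 12 nM

Compound 2 sits level with compound 1 within the scatter (a 1.4-fold lower number from compound 1 to compound 2 (0.14 log units; within the scatter)), and both lie well above compound 3. Compound 4 `CC(Nc1ccccc1Oc1cccc(N)c1)=C1C(=O)CC(c2ccccc2)CC1=O` has not been measured. It carries 3-aminophenyl in place of 3,4-dimethoxyphenyl on an oxygen on an aromatic ring.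

Among the measured compounds shown here, no measured step makes exactly this change. The closest evidence is a large one (a 13-fold lower number from compound 2 to compound 3 (1.12 log units; beyond the scatter)), amino in place of methoxy on an aromatic carbon. Another large step (an 18-fold lower number from compound 1 to compound 3 (1.26 log units; beyond the scatter)) also ends at the amino compound 3. However, 3-aminophenyl is not 4-amino-3-methoxyphenyl, so only part of that gain is expected to carry over. In this assay, for the measured compounds named here, a moderate step to a lower number is therefore expected, smaller than the one to compound 3. The expected step is a 3.2-fold lower number from compound 2 to compound 4 (0.51 log units; beyond the scatter) on this estimate. For compound 4 the estimated value is 50 nM, with an expected range of 12 nM to 200 nM.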

Compound 4, half-maximal inhibitory concentration: 42 nM
Compound 4: middle estimate off by 1.2-fold (0.08 log units), on the high side, and the stated range covers the measured number.
By their numbers in this assay, from the lowest: compound 3; then compound 4; then compounds 2 and 1 (each within the scatter of the next).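

In this assay, a ring bearing a single amino group, 3-aminophenyl, already gives much of the gain seen with amino substitution, with a 3.8-fold lower number from compound 2 to compound 4 (0.58 log units; beyond the scatter) and a 5.2-fold lower number from compound 1 to compound 4 (0.72 log units; beyond the scatter), so this position does not need the methoxy of 4-amino-3-methoxyphenyl for a step beyond the scatter. That group still holds an edge over 3-aminophenyl, with a 3.5-fold higher number from compound 3 to compound 4 (0.54 log units; beyond the scatter), although this change moves the amino group and removes the methoxy at once, so the two contributions cannot be told apart. Nothing measured here accounts for these differences.

The compounds shown leave open whether the remaining gap follows the place of the amino group or the methoxy, which 4-aminophenyl would help to separate. They also leave open whether the amino group itself is needed, which a hydroxyl or dimethylamino group in its place would test.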